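Methoxy to benzyloxy on the core of compound 1

A few compounds are considered here, and "the series" means these few. Any claim that something is new, unique, unknown or untested is made for them only; others in the source may bear on it.

Compound 1 `CCOS(=O)(=O)/C=C/c1ccc(OCC2=CC[C@@H]3C(C(=O)Nc4ccc(Oc5ccccc5)cc4)=CO[C@@H](OC)[C@H]23)cc1` is the starting point for this step. In an ADME assay on CHO cells (Cricetulus griseus) for cytotoxicity, read by MTT assay, with a stated time of 24 h (on this read-out lower numbers stand for stronger inhibition and higher numbers for weaker inhibition), compound 1 gives > 200000 nM as its reading, and this is a limit of the assay and not a number. Compound 2 `CCOS(=O)(=O)/C=C/c1ccc(OCC2=CC[C@@H]3C(C(=O)Nc4ccc(Oc5ccc(-c6ccccc6)cc5)cc4)=CO[C@@H](OC)[C@H]23)cc1` gives > 200000 nM in this assay as its reading, and this too is a limit.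

Compound 3 `CCOS(=O)(=O)/C=C/c1ccc(OCC2=CC[C@@H]3C(C(=O)Nc4ccc(Oc5ccccc5)cc4)=CO[C@@H](OCc4ccccc4)[C@H]23)cc1` changes methoxy to benzyloxy, with phenyl in place of hydrogen on a saturated chain carbon bound to an oxygen on a saturated carbon, counted as phenyl in place of hydrogen on a saturated chain carbon bound to an oxygen on a saturated carbon in full.

Among the measured compounds shown here, the only measured step bearing on this is a step that the two limits leave unreadable from compound 1 to compound 2 and it has phenyl in place of hydrogen on an aromatic carbon, a different place from the change in compound 3. For the measured compounds named here, no size of step can be carried over from compound 2 because the limit of > 200000 nM in this assay, at which 2 of the 2 values shown sit, is all the series shows so far. The expected change is a number no higher from compound 1 to compound 3 (the limit leaves the size open) and no direction is expected in this assay beyond the scatter. Compound 3 is estimated at 200000 nM with an expected range of 80000 nM to 400000 nM and will most likely be reported only as a limit again.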

Compound 3, half-maximal inhibitory concentration: 62000 nM
For compound 3 the middle estimate is 3.2-fold (0.51 log units) above the measured one; measured number below the stated range.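

In this assay, among the compounds shown here, the methoxy to benzyloxy change gives the first readable step: an at least 3.2-fold lower number from compound 1 to compound 3 (0.50 log units; beyond the scatter). This shows that the reading can move with phenyl placed on a saturated chain carbon bound to an oxygen on a saturated carbon, whereas the step with phenyl on an aromatic carbon, from compound 1 to compound 2, cannot be read. The reading of compound 1 is a limit of the assay and not a number, so the step may be larger than printed, and most of the series still gives no number to compare: the limit of > 200000 nM in this assay, at which 2 of the 3 values shown sit.

The compounds shown do not separate an effect of the phenyl ring itself from that of any larger group at this place, a question that an ethoxy group, a longer alkyl chain or a cyclohexylmethoxy group would address. Also open, as far as these compounds go, are how an amine or a carboxylic acid on the benzyl ring would read, and whether the same methoxy to benzyloxy change would shift the reading on compound 2.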